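Permeability notes: isobutyl to aryloxy swap on the core

This account rests on a few compounds, and the source may have more. Where it says the series, first, only, none or still open, it means among the compounds named here.

Three members of the series have been run in an ADME assay for permeability, using PAMPA, with a stated time of 30 min, at pH 7.4; a lower number here means that the compound crosses the layer more slowly, a higher number that the compound crosses the layer faster. Compound 1 `COc1cccc(CNCCCNc2ccnc3cc(Cc4cc(C)cc(C)c4)ccc23)c1O` gives 23 10^-6 cm/s. Compound 2 `COc1cccc(CNCCCNc2ccnc3cc(Cc4ccc(C#N)cc4)ccc23)c1O` gives 23 10^-6 cm/s. Compound 3 `COc1cccc(CNCCCNc2ccnc3cc(CC(C)C)ccc23)c1O` gives 23 10^-6 cm/s, level with the other two at the digits shown. The steps among them, no change at the digits printed from compound 1 to compound 2 (within the scatter), no change at the digits printed from compound 1 to compound 3 (within the scatter) and no change at the digits printed from compound 2 to compound 3 (within the scatter), all stay within the scatter, so the group carried on a saturated chain carbon bound to an aromatic carbon has so far left the read-out untouched across 3,5-dimethylphenyl, 4-cyanophenyl and isopropyl.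

Compound 4 `COc1ccccc1Oc1ccc2c(NCCCNCc3cccc(OC)c3O)ccnc2c1` is not yet measured. It differs from compound 3 in one place: 2-methoxyphenoxy in place of isobutyl on an aromatic carbon. Among the compounds with values here, the group now sits directly on an aromatic carbon of the core rather than on a saturated chain carbon, and it is oxygen-linked, which no measured pair tests. The three measured steps bear on it only loosely; none of them moved the number. The expectation is therefore a step of a 1.2-fold lower number from compound 3 to compound 4 (0.06 log units; within the scatter), within the scatter. Compound 4 is estimated at 20 10^-6 cm/s, with a range from 9 10^-6 cm/s to 35 10^-6 cm/s.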

Compound 4, apparent permeability: 317 10^-6 cm/s
Compound 4: the middle estimate sits 16-fold (1.20 log units) below what was measured; the measured number lies above the stated range.
By their numbers in this assay, from the lowest: compounds 1, 2 and 3 (each within the scatter of the next); then compound 4.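

The position on the aromatic carbon of the core is not indifferent to what it carries in this assay: the change to 2-methoxyphenoxy gives a 14-fold higher number from compound 3 to compound 4 (1.14 log units; beyond the scatter) and a 14-fold higher number from compound 2 to compound 4 (1.14 log units; beyond the scatter) and a 14-fold higher number from compound 1 to compound 4 (1.14 log units; beyond the scatter). The flat read-out across the first three compounds therefore holds only for those carbon-linked groups and does not extend to this oxygen-linked one. No measurement here accounts for the size of this step.

The change brings in the oxygen link, the ring and the methoxy together, so the compounds shown leave open which of these goes with the step; a plain phenoxy and a 2-methoxybenzyl on the same aromatic carbon would separate them. Going by these compounds, whether a nitrogen link, as in an anilino group, behaves the same way also stays open.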